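This account rests on a few compounds, and the source may have more. Where it says the series, first, only, none or still open, it means among the compounds named here.

Compound 1 `C=C1[C@H](C)CCC[C@]1(C)CC/C(C)=C/CC1=C(O)C(=O)C=C(N[C@H](C(=O)O)[C@H](C)O)C1=O`: in an ADME assay on KB cells (Homo sapiens) for cytotoxicity, with a stated time of 48 h (on this read-out higher numbers stand for weaker inhibition and lower numbers for stronger inhibition), compound 1 gives > 10 ug/mL, which is a limit of the assay and not a number.
Compound 2 `C=C1[C@H](C)CCC[C@]1(C)CC/C(C)=C/CC1=C(O)C(=O)C=C(N[C@H](C(=O)O)C(C)C)C1=O`: in this assay compound 2 gives > 10 ug/mL, again a limit of the assay.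
Compound 3 `CC1=CCC[C@](C)(CC/C(C)=C/CC2=C(O)C(=O)C=C(N[C@H](C(=O)O)[C@H](C)O)C2=O)[C@@H]1C`: in this assay compound 3 gives > 10 ug/mL, also a limit of the assay.

The change from compound 1 to compound 2 is isopropyl in place of 1-hydroxyethyl on a saturated chain carbon bound to an amine nitrogen and a carbonyl carbon, and its step is a step that the two limits leave unreadable from compound 1 to compound 2, as all values sit at the limit of > 10 ug/mL in this assay, at which 3 of the 3 values shown sit. The two cores differ by a group of 9 heavy atoms (9 carbon; one six-membered non-aromatic ring of carbon only) in place of a group of 9 heavy atoms (9 carbon; one six-membered non-aromatic ring of carbon only), on a saturated chain carbon, two bonds along the chain from a double-bonded chain carbon, and that step is a step that the two limits leave unreadable from compound 1 to compound 3. Compound 4 `CC1=CCC[C@](C)(CC/C(C)=C/CC2=C(O)C(=O)C=C(N[C@H](C(=O)O)C(C)C)C2=O)[C@@H]1C` carries the same change on the core of compound 3, namely (isopropyl in place of 1-hydroxyethyl on a saturated chain carbon bound to an amine nitrogen and a carbonyl carbon). Given that every measured value sits at the limit of > 10 ug/mL in this assay, at which 3 of the 3 values shown sit, the expected step that the limit leaves unreadable from compound 3 to compound 4 cannot be sized from the data. Compound 4 is therefore estimated at 15 ug/mL, between 7 ug/mL and 40 ug/mL, most likely reported only as a limit.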

Compound 4, half-maximal inhibitory concentration: > 10 ug/mL
Compound 4: only a limit was reported; the forecaster's own chance of this, stated with the estimate: 80%; the middle value lies beyond the limit too.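

The steps from compound 3 to compound 4 and from compound 2 to compound 4 cannot be read, because all the compounds sit at one limit: the limit of > 10 ug/mL in this assay, at which 4 of the 4 values shown sit. The compounds shown leave open whether isopropyl in place of 1-hydroxyethyl, or either core, changes the read-out at all.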